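Notes on compound 3 in the KYSE-450 series

A few compounds are considered here, and "the series" means these few. Any claim that something is new, unique, unknown or untested is made for them only; others in the source may bear on it.

Two compounds have numbers in a functional assay on KYSE-450 cells (Homo sapiens) for inhibition, read by CCK-8 assay, with a stated time of 48 h; a higher number here means a weaker inhibitor, a lower number a stronger inhibitor. Compound 1 `COc1ccc(CN(C(=O)CN2CCN(C(=O)OC(C)(C)C)CC2)c2cc(OC)c(OC)c(OC)c2)cc1` gives 8170 nM there. Compound 2 `COc1cc(N(Cc2ccc(Br)cc2)C(=O)CSC(=S)N2CCN(C(=O)OC(C)(C)C)CC2)cc(OC)c1OC` gives 10700 nM in this assay, the higher of the two numbers, yet its gap to compound 1 lies within the usual scatter, so no order between the two can be read. Compound 3 `COc1ccc(CN(C(=O)CSC(=S)N2CCN(C(=O)OC(C)(C)C)CC2)c2cc(OC)c(OC)c(OC)c2)cc1N` is not yet measured; it differs from compound 2 as follows: 3-amino-4-methoxyphenyl in place of 4-bromophenyl on a saturated chain carbon bound to an amide-type nitrogen. For the measured compounds named here, no measured pair carries this change, so its effect is unknown. Expected for compound 3 in this assay is 7000 nM, range 2500 nM to 20000 nM. The expected step of a 1.5-fold lower number from compound 2 to compound 3 (0.18 log units; within the scatter) is small, not beyond the scatter.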

Compound 3, half-maximal inhibitory concentration: 208 nM
Beside the measured number, compound 3's estimate is 34-fold (1.53 log units) above it; the measured number lies below the stated range.
By their numbers in this assay, from the lowest: compound 3; then compounds 1 and 2 (each within the scatter of the next).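

In this assay the step of a 51-fold lower number from compound 2 to compound 3 (1.71 log units; beyond the scatter) shows that this place, on a saturated chain carbon bound to an amide-type nitrogen, is sensitive to the group it carries, which compounds 1 and 2 could not show. The 4-bromobenzyl to 3-amino-4-methoxybenzyl change is the only one read here, and nothing at hand accounts for the size of its step.

On these data alone, the change alters two substituents on the ring at once, so it stays open whether the amino group, the methoxy group or both go with the step. An unsubstituted phenyl or a ring bearing a carboxylic acid in this place would show how far the result extends.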